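A few compounds are considered here, and "the series" means these few. Any claim that something is new, unique, unknown or untested is made for them only; others in the source may bear on it.

The set holds three measured compounds and one still awaiting measurement. Compound 1 `COc1cccc(-c2ccc3c(NC(=O)c4ccc(N5CCN(C)CC5)cc4F)n[nH]c3c2)c1F` and compound 2 `CCN1CCN(c2ccc(C(=O)Nc3n[nH]c4cc(-c5cccc(OC)c5F)ccc34)cc2C(F)(F)F)CC1` share their core with compound 3 `COc1ccc(F)c(-c2ccc3c(NC(=O)c4ccc(N5CCCN(C)CC5)cc4)n[nH]c3c2)c1F` but differ in the aromatic substituents they carry. In a functional assay on KG-1 cells (Homo sapiens) for antiproliferative activity, read by CCK-8 assay, with a stated time of 72 h (a higher number here means a weaker inhibitor, a lower number a stronger inhibitor), compound 1 reaches only a limit of the assay, > 1000 nM, and no number. Compound 2 likewise gives only a limit in this assay, > 1000 nM. Within the data shown here, compound 3, by contrast, yields a real value in this assay, 51.5 nM, and so stands as the only measured number among the three, the other two sitting at the limit of > 1000 nM in this assay, at which 2 of the 3 values shown sit.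

Compound 4 `COc1ccc(F)c(-c2ccc3c(NC(=O)c4ccc(N5CCN(C)CC5)cc4)n[nH]c3c2)c1F` is drawn from compound 3 by a single change: 4-methylpiperazin-1-yl in place of 4-methyl-1,4-diazepan-1-yl on an aromatic carbon. Among the measured compounds shown here, no step between two measured compounds isolates this change, so the data themselves do not set its size. Compound 1 also carries the 4-methylpiperazin-1-yl group and sits at a limit, yet it differs from compound 3 in more than one place and cannot be read as a step. The expectation is that the change from compound 3 to compound 4 shifts this assay by a 1.6-fold higher number from compound 3 to compound 4 (0.19 log units; within the scatter), a step not beyond the usual scatter. Compound 4 is therefore estimated at 80 nM, expected to fall between 25 nM and 300 nM.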

Compound 4, half-maximal inhibitory concentration: 41.5 nM
Compound 4: middle estimate off by 1.9-fold (0.29 log units), on the high side, within the range that was stated.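

The step at this position, in this assay, is a 1.2-fold lower number from compound 3 to compound 4 (0.09 log units; within the scatter), so on the aromatic carbon para to a large group, 4-methylpiperazin-1-yl and 4-methyl-1,4-diazepan-1-yl cannot be told apart in this pair. Among these compounds, until now compound 3 held the only number in the set, and nothing showed whether that number depended on the seven-membered ring; compound 4 shows that, with these other substituents in place, the six-membered ring gives a value within the scatter of it. No measurement shown here bears on why the two rings read alike.

What the compounds shown leave open is how this position responds to a morpholin-4-yl ring, to a piperazin-1-yl ring with a hydrogen in place of the methyl, or to an open-chain amine such as dimethylamino. Also open, on these data alone, is whether the two rings stay level with other aromatic substituents on the shared core; this single pair speaks only for the substituents that compound 3 and compound 4 carry.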